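Taking One Trifluoromethyl Off Compound 1

The source may hold more compounds than are shown below. What is called first, only, known or untested is meant among the compounds shown, and "the series" means these compounds.

Of the compounds shown here, two have been measured so far. Compound 1 `COc1cc(-c2nn(-c3cccc(NC(=O)Nc4cc(C(F)(F)F)cc(C(F)(F)F)c4)c3)cc2-c2ccncc2)ccc1Cl` in a functional assay on OVCAR-3 cells (Homo sapiens) for inhibition, read by sulforhodamine B assay, with a stated time of 48 h (a lower number here means a stronger inhibitor of growth, a higher number a weaker inhibitor of growth), gives 411 nM. Compound 2 `O=C(Nc1cccc(-n2cc(-c3ccncc3)c(-c3ccc(Cl)c(O)c3)n2)c1)Nc1ccc(Cl)c(Cl)c1` in this assay gives 1050 nM. Compound 1 therefore holds the lower of the two numbers, and compound 2 stands at a higher number, a gap beyond the scatter. Since the two differ in several places at once, their values show only where each stands, not what any single change does.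

Compound 3 `COc1cc(-c2nn(-c3cccc(NC(=O)Nc4cccc(C(F)(F)F)c4)c3)cc2-c2ccncc2)ccc1Cl` differs from compound 1 in exactly one place: hydrogen in place of trifluoromethyl on an aromatic carbon. Among the compounds with values here, no pair of measured compounds covers this change, so the size of the step is not known from the data. The author expects a small step toward a higher number, near the edge of the scatter or a little beyond it, with the direction uncertain. Compound 3 is accordingly estimated at 700 nM, with a range from 300 nM to 1800 nM. This estimate means an expected step of a 1.7-fold higher number from compound 1 to compound 3 (0.23 log units; within the scatter).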

Compound 3, concentration for 50% growth inhibition: 579 nM
Compound 3: middle estimate off by 1.2-fold (0.08 log units), on the high side; the measured number falls inside the stated range.
By their numbers in this assay, from the lowest: compounds 1, 3 and 2 (each within the scatter of the next, the first and the last beyond it).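

Hydrogen in place of trifluoromethyl, on an aromatic carbon meta to a trifluoromethyl group, gives a 1.4-fold higher number from compound 1 to compound 3 (0.15 log units; within the scatter) in this assay. Within the data shown here, this is the first single-place comparison in the set, and unlike the gap between compound 1 and compound 2, which spans several changes at once, it isolates one position: on this pair, losing the 4 heavy atoms of one trifluoromethyl leaves the reading within the scatter, so with the remaining trifluoromethyl in place, the second is not needed to hold the number in this assay. Nothing available explains why this step is as small as it is.

The compounds shown leave open whether this tolerance extends to groups other than hydrogen at the same position, such as an amine or a carboxylic acid, and whether it would hold for a longer chain there. They also leave open what happens if the remaining trifluoromethyl is replaced by hydrogen as well, since this single step says nothing about that second position.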